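Changing the group on the amine: expected cytotoxicity of compound 3

A few compounds are considered here, and "the series" means these few. Any claim that something is new, unique, unknown or untested is made for them only; others in the source may bear on it.

Measured so far:
- compound 1 `N#CC1=C(N)N(c2ccc(S(N)(=O)=O)cc2)C2=C(C(=O)CCC2)C1c1ccc(Cl)cc1Cl` gives 40% in a functional assay on Ehrlich cells (Mus musculus) for cytotoxicity, read by trypan blue exclusion, with a stated time of 2 h, tested at 10 ug/mL; on this read-out higher numbers stand for a stronger effect at the one concentration tested and lower numbers for a weaker effect
- compound 2 `CC(=O)CC(=O)NC1=C(C#N)C(c2ccc(Cl)cc2Cl)C2=C(CCCC2=O)N1c1ccc(S(N)(=O)=O)cc1` gives 40% in this assay

Compound 2 stands level with compound 1 at the digits shown; the step of no change at the digits printed from compound 1 to compound 2 (within the scatter) lies within the scatter, so attaching the (2-oxopropyl)carbonyl group to the amine nitrogen made no visible difference in this cell read-out.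

Compound 3 `CCO/C=N/C1=C(C#N)C(c2ccc(Cl)cc2Cl)C2=C(CCCC2=O)N1c1ccc(S(N)(=O)=O)cc1` is not yet measured. It differs from compound 2 in one place: a group of 5 heavy atoms (3 carbon, 1 nitrogen, 1 oxygen; no ring) in place of a group of 7 heavy atoms (4 carbon, 1 nitrogen, 2 oxygen; no ring), on a double-bonded ring carbon. Among the compounds with values here, the only measured step that bears on this position is the one from compound 1 to compound 2, which was flat. With one flat step and nothing else to go on, no shift beyond the scatter is expected for this assay, so the step of no change at the digits printed from compound 2 to compound 3 (within the scatter) is estimated to be close to nothing. Compound 3 is therefore expected to give about 40%, in a range from 25% to 55%.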

Compound 3, a percentage reported as activity, at one concentration (the size of the read-out at that concentration, not a potency): 30%
Estimate against measurement, compound 3: 10 percentage points above, within the range that was stated.
By their numbers in this assay, from the lowest: compounds 3, 1 and 2 (each within the scatter of the next).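

Three different substituents have now been compared on this double-bonded ring carbon, and none separates from the others in this assay: replacing the ((2-oxopropyl)carbonyl)amino group gives a number 10 percentage points lower from compound 2 to compound 3 (within the scatter) and replacing the plain amine gives a number 10 percentage points lower from compound 1 to compound 3 (within the scatter). The entering group has no hydrogen-bond donor and the ((2-oxopropyl)carbonyl)amino group has one, yet that difference in count comes with no shift beyond the scatter in this read-out. Nothing measured here offers an explanation for this flat picture.

From the compounds shown here alone, whether a longer alkoxy chain, a carboxylic acid or a simple acetyl group at this position would move the read-out beyond the scatter stays open. Going by these compounds, all three compounds also share the 2,4-dichlorophenyl, 4-sulfamoylphenyl and cyano groups, so the contribution of each to the cytotoxicity remains unknown.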